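This account rests on a few compounds, and the source may have more. Where it says the series, first, only, none or still open, it means among the compounds named here.

Measured in a functional assay on Hs 683 cells (Homo sapiens) for inhibition, read by MTT assay, with a stated time of 72 h; a lower number here means a stronger inhibitor, a higher number a weaker inhibitor:
- Compound 1 `CCC(=O)O[C@@H](/C(C)=C/[C@@H](C)c1oc(CC)c(C)c(=O)c1C)[C@H](C)[C@@H](OC(=O)CC(C)C)[C@@H](C)c1oc([C@@H](C)[C@@H](O)CC)c(C)c(=O)c1C`: 13000 nM
- Compound 2 `CCC(=O)[C@@H](C)c1oc([C@H](C)[C@@H]2O[C@](O)([C@@H](C)c3oc(CC)c(C)c(=O)c3C)[C@@H](C)[C@@H](O)[C@@H]2C)c(C)c(=O)c1C`: > 100000 nM, a limit
- Compound 3 `CCC(=O)[C@H](C)c1oc([C@H](C)[C@@H]2O[C@](O)([C@@H](C)c3oc(CC)c(C)c(=O)c3C)[C@@H](C)[C@@H](O)[C@@H]2C)c(C)c(=O)c1C`: > 100000 nM, a limit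

Compound 1 alone gives a number. The other two compounds stand at the limit of > 100000 nM in this assay, at which 2 of the 3 values shown sit.

Compound 4 `CCc1oc([C@H](C)/C=C(\C)[C@H](OC(C)=O)[C@H](C)[C@@H](OC(=O)CC(C)C)[C@@H](C)c2oc([C@@H](C)[C@@H](O)CC)c(C)c(=O)c2C)c(C)c(=O)c1C` differs from compound 1 in one place: hydrogen in place of methyl on a saturated chain carbon bound to a carbonyl carbon. In other words, propanoyloxy becomes acetoxy.

Going by the values given here, the only measured step is a step that the two limits leave unreadable from compound 2 to compound 3. It rests on (the fact that compounds 2 and 3 differ only in the configuration as drawn), a different kind of change, so it gives no size to carry over. Among the compounds with values here, no measured step bears directly on the move from propanoyloxy to acetoxy. The expectation therefore starts from compound 1 at 13000 nM, and in this assay no step beyond the scatter is expected in either direction. The expected step is no change at the digits printed from compound 1 to compound 4 (within the scatter). For compound 4 the estimated value is 13000 nM, with an expected range of 5000 nM to 35000 nM.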

Compound 4, half-maximal inhibitory concentration: 30000 nM
For compound 4 the middle estimate is 2.3-fold (0.36 log units) below the measured one; low and high end bracket the measured number.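

In this assay the change from propanoyloxy to acetoxy gives a 2.3-fold higher number from compound 1 to compound 4 (0.36 log units; beyond the scatter). This is the first readable step among these compounds, and it shows that this place, a saturated chain carbon bound to a carbonyl carbon, responds to the loss of a single methyl, with the number moving toward the weaker side while compound 4 still gives a number and not a limit. Nothing given here bears on why the step occurs.

The compounds shown leave open whether a longer chain, such as butanoyloxy, would move the number the other way, or whether the trend is confined to this one pair. They also leave open what a free hydroxyl in place of the acetoxy would give in this assay.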